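The source may report more compounds than this note shows. Statements on the series, on what has been measured and on what is new or still open speak of the compounds shown alone.

Measured so far in an ADME assay on MDCK cells (Canis lupus familiaris) for cytotoxicity, read by MTT assay, with a stated time of 2 days; a lower number here means that less compound is tolerated, a higher number that more compound is tolerated:

- compound 1, `[N-]=[N+]=NCCCc1ccc(-c2ccc(-c3ccc(-c4cccs4)s3)s2)s1`: > 100000 nM, a limit of this assay
- compound 2, `[N-]=[N+]=NCCCc1ccc(-c2ccc(-c3cccs3)s2)s1`: > 200000 nM, a limit of this assay
- compound 3, `BrCCCCc1ccc(-c2ccc(-c3ccc(-c4cccs4)s3)s2)s1`: "not determined" (no result reported)

The core of compound 3 differs from the core of compound 1 by bromomethyl in place of azido on a saturated chain carbon, three bonds along the chain from an aromatic carbon. Compound 4, `BrCCCCc1ccc(-c2ccc(-c3cccs3)s2)s1`, is not yet measured. Compound 4 differs from compound 3 by hydrogen in place of thiophen-2-yl on an aromatic carbon, and compound 2 differs from compound 1 by hydrogen in place of thiophen-2-yl on an aromatic carbon; the two place lines read the same, so this is the same change at the same kind of place. The measured instance gives a step that the two limits leave unreadable from compound 1 to compound 2, since both values sit at the limit of > 100000 nM in this assay, at which 1 of the 3 values shown sits, and (the limit of > 200000 nM in this assay, at which 1 of the 3 values shown sits). The step from compound 3 to compound 4 in this assay is therefore expected to be equally unreadable, resting only on that pair. Compound 4 is expected to give about 300000 nM in this assay.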

Compound 4, half-maximal cytotoxic concentration: 23800 nM
Estimate against measurement, compound 4: 13-fold (1.10 log units) above, and the stated range ends above it.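

In this assay bromomethyl in place of azido, on the core of compound 2, gives an at least 8.4-fold lower number from compound 2 to compound 4 (0.92 log units; beyond the scatter). From the compounds shown here alone, compound 2 gives > 200000 nM, which is a limit of this assay, so the true size of the step remains unknown. This shows the change on one core only and does not show that it carries to the core of compound 1: compound 3 has no reported result, and the steps that would compare the two cores cannot be read.

The compounds shown leave open whether bromomethyl in place of azido lowers the number on the core of compound 1. They also leave open how an amine or a carboxylic acid in place of azido would read in this assay.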